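Hydroxy on the core of compound 1: an alpha-1 affinity estimate

A few compounds are considered here, and "the series" means these few. Any claim that something is new, unique, unknown or untested is made for them only; others in the source may bear on it.

Three compounds share one core and differ only in a single group on it. Compound 1 `c1ccc(Oc2ccc(Cc3nc4ccccc4[nH]3)cc2)cc1` carries a hydrogen at the spot in question; in an assay on membranes from brain for binding affinity to Adrenergic receptor alpha-1 (Rattus norvegicus) (on this read-out lower numbers stand for stronger inhibition and higher numbers for weaker inhibition), compound 1 gives 4200 nM. This is the highest of the three numbers, so compound 1 inhibits least strongly among them. Compound 2 `O=[N+]([O-])c1ccc2[nH]c(Cc3ccc(Oc4ccccc4)cc3)nc2c1` carries a nitro and gives 1200 nM in this assay; the step of a 3.5-fold lower number from compound 1 to compound 2 (0.54 log units; beyond the scatter) is modest yet beyond the scatter. Compound 3 `N#Cc1ccc2[nH]c(Cc3ccc(Oc4ccccc4)cc3)nc2c1` carries a cyano and gives 3400 nM; the step of a 1.2-fold lower number from compound 1 to compound 3 (0.09 log units; within the scatter) stays within the scatter, and between compound 2 and compound 3 the step is a 2.8-fold higher number from compound 2 to compound 3 (0.45 log units; beyond the scatter).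

Compound 4 `Oc1cccc2[nH]c(Cc3ccc(Oc4ccccc4)cc3)nc12` is not yet measured. It differs from compound 1 by hydroxy in place of hydrogen on an aromatic carbon. Among the measured compounds shown here, no measured step puts a hydroxy on the core, so the two known steps bear on this change only loosely: one group made the number modestly smaller, the other left it unchanged within the scatter. A small effect in this assay, if any, is therefore expected, in a downward direction at most. For compound 4 the expected step is a 1.2-fold lower number from compound 1 to compound 4 (0.08 log units; within the scatter). Compound 4 is estimated at 3500 nM, with a range from 1200 nM to 9000 nM.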

Compound 4, half-maximal inhibitory concentration: 5500 nM
For compound 4 the middle estimate is 1.6-fold (0.20 log units) below the measured one; the range from low to high includes it.
By their numbers in this assay, from the lowest: compound 2; then compounds 3, 1 and 4 (each within the scatter of the next).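

In this assay, the step of a 1.3-fold higher number from compound 1 to compound 4 (0.12 log units; within the scatter) shows that a hydroxy on this aromatic carbon, ortho to a fused ring and meta to a fused ring, cannot be told apart from the hydrogen of compound 1. The earlier compounds had shown such a flat result only for a cyano, whereas a hydroxy is counted as both a hydrogen-bond donor and a hydrogen-bond acceptor, so this flat result now extends to a second, quite different group, and of the three groups on the core only the nitro, with a 3.5-fold lower number from compound 1 to compound 2 (0.54 log units; beyond the scatter), gives a step beyond the scatter. The data shown offer no explanation for why the hydroxy changes so little.

The compounds shown leave open whether an amine, a methoxy or a carboxylic acid at this same place would also stay within the scatter or would move the number as the nitro did. They also leave open whether a hydroxy on another carbon of this ring would behave as it does here, since the hydroxy is shown at this one place only.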